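A few compounds are considered here, and "the series" means these few. Any claim that something is new, unique, unknown or untested is made for them only; others in the source may bear on it.

Measured compounds
- Compound 1, `Cc1cc(OCCCCCCC[N+]23CCN(CC2)CC3)ccc1-n1cc(C(=O)Nc2cc(F)cc(F)c2)c(=O)c2ccc(N(C)C)nc21`: reported as "not active" (no number reported) in an assay on LX2 cells for inhibition of COL1A1 promoter (Homo sapiens), read by a luciferase reporter, with a stated time of 24 h, tested at 20 uM (a lower number here means a weaker effect, a higher number a stronger effect of the compound at the concentration tested), with no number given.
- Compound 2, `Cc1ccc(-n2cc(C(=O)Nc3cc(F)cc(F)c3)c(=O)c3ccc(N(C)C)nc32)cc1OCCCCCCC[N+]12CCN(CC1)CC2`: 5.07% in this assay.

Going by the values given here, compound 2 carries the only number in this assay; the one other entry, compound 1, has no number. Compound 2 therefore stands alone, and its reading is a single-concentration inhibition value that is small on its own terms.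

Compound 3, `CN(C)c1ccc2c(=O)c(C(=O)Nc3cc(F)cc(F)c3)cn(-c3ccc(Cl)c(OCCCCCCC[N+]45CCN(CC4)CC5)c3)c2n1`, is the next member to be measured in this assay. It differs from compound 2 by chloro in place of methyl on an aromatic carbon.

Among the compounds with values here, no measured step between two compounds is available here, so nothing is known about how a change of this kind moves the read-out. The expectation for the step from compound 2 to compound 3 in this assay is a number 0.1 percentage points lower from compound 2 to compound 3 (within the scatter), that is, no movement beyond the usual scatter. Compound 3 is accordingly estimated at 5% in this assay, with a range from -5% to 15%.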

Compound 3, a percentage reported as inhibition, at one concentration (the size of the read-out at that concentration, not a potency): 8.08%
For compound 3 the middle estimate is 3.1 percentage points below the measured one, and the stated range covers the measured number.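

In this assay, chloro in place of methyl on this aromatic carbon, ortho to a large group and para to a large group, gives a number 3 percentage points higher from compound 2 to compound 3 (within the scatter). Going by these compounds alone, this is the first measured step, and it shows that this exchange of one heavy atom for another, with no change in the count of hydrogen-bond donors or acceptors, does not move the read-out beyond the usual scatter. Nothing available explains this result.

From the compounds shown here alone, whether a larger or different group on this carbon, such as methoxy, trifluoromethyl or an amine, would move the read-out beyond the scatter remains open. Also open, going by these compounds, is whether a longer chain in place of the present one would change the small inhibition seen for compound 2 and compound 3.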